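The source may hold more compounds than are shown below. What is called first, only, known or untested is meant among the compounds shown, and "the series" means these compounds.

Three compounds that share a core have been examined in an ADME assay on microsomes from liver (Rattus norvegicus) for metabolic stability, with a stated time of 10 min (a higher number here means that more of the compound is left, a lower number that less of the compound is left), and a fourth is still to be tested. There, compound 1 (`COc1ccc2oc(-c3cn4nc(OC)sc4n3)cc2c1`) has 38% remaining and compound 3 (`COc1nn2cc(-c3cc4ccc(OC)c(OC)c4o3)nc2s1`) has 3% remaining. Compound 2 (`c1ccc(Sc2nn3cc(-c4cc5ccccc5o4)nc3s2)cc1`) has no number to stand on, since its result reads "not determined" (no result reported) and it cannot be placed beside the other two. Compound 4 (`CCSc1nn2cc(-c3cc4ccccc4o3)nc2s1`) departs from compound 2 in one place, with ethyl in place of phenyl on a sulfur, so that phenylsulfanyl becomes ethylsulfanyl. Among the compounds with values here, no measured step exists for this change, and compound 2 offers no starting point for one. In this assay a step beyond the scatter is not expected in either direction, although this expectation has nothing measured behind it. Within the data shown here, the only numbers available as guides are those of compound 1 at 38% remaining and compound 3 at 3% remaining, which leaves the estimate wide. For compound 4 the expected value is 15% remaining, with an estimated range from 3% to 45% remaining.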

Compound 4, percent of the compound remaining: 35%
For compound 4 the middle estimate is 20 percentage points below the measured one; the range from low to high includes it.
By their numbers in this assay, from the lowest: compound 3; then compounds 4 and 1 (each within the scatter of the next).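

Within the data shown here, compound 2 has no number in this assay, so no step from it to compound 4, at 35%, can be read. The compounds shown leave open how phenylsulfanyl and ethylsulfanyl compare on the shared core. No available evidence bears on this result.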